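Three Analogues Measured, a Fourth Awaited in the Same Assay

The source may report more compounds than this note shows. Statements on the series, on what has been measured and on what is new or still open speak of the compounds shown alone.

Of the compounds shown here, three built on one shared core have been tested in a functional assay on HT-29 cells (Homo sapiens) for cytotoxicity, read by MTT assay, with a stated time of 24 h, tested at 80 ug/mL; on this read-out higher numbers stand for a stronger effect at the one concentration tested and lower numbers for a weaker effect. Compound 1 `Cn1c(-c2ccc(NC(=O)CCl)cc2)nc(-c2ccccc2)c1-c1ccccc1` gives 76.1%. Compound 2 `Cn1c(-c2ccc(NC(=O)CSc3nc4ccccc4o3)cc2)nc(-c2ccccc2)c1-c1ccccc1` gives 81.5%, and compound 3 `Cn1c(-c2ccc(NC(=O)CSC3=NCCS3)cc2)nc(-c2ccccc2)c1-c1ccccc1` gives 75.2%. Compound 2 holds the highest of the three numbers, with compound 1 nearest and compound 3 furthest, yet both of those gaps fall within the scatter, so the three compounds are not separated by this read-out.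

Compound 4 `Cn1c(-c2ccc(NC(=O)CN3CCN(c4ccccc4)CC3)cc2)nc(-c2ccccc2)c1-c1ccccc1` has not yet been measured. It differs from compound 2 in a single place: 4-phenylpiperazin-1-yl in place of (1,3-benzoxazol-2-yl)sulfanyl on a saturated chain carbon bound to a carbonyl carbon. Every change seen so far sits at that same saturated chain carbon bound to a carbonyl carbon, and none of them moved the number beyond the scatter: a number 5.4 percentage points higher from compound 1 to compound 2 (within the scatter), a number 0.9 percentage points lower from compound 1 to compound 3 (within the scatter) and a number 6.3 percentage points lower from compound 2 to compound 3 (within the scatter). With three exchanges at this position all leaving the read-out flat, the reasonable expectation is that the step from compound 2 to compound 4 is also small, and the expected step is a number 4.5 percentage points lower from compound 2 to compound 4 (within the scatter). Compound 4 is therefore estimated at 77% in this assay, with a range from 64% to 88%.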

Compound 4, a percentage reported as activity, at one concentration (the size of the read-out at that concentration, not a potency): 63.7%
Compound 4: middle estimate off by 13.3 percentage points, on the high side, outside the stated range (below it).
By their numbers in this assay, from the lowest: compound 4; then compounds 3, 1 and 2 (each within the scatter of the next).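

In this assay, the saturated chain carbon bound to a carbonyl carbon proves not to be indifferent to what it carries: placing 4-phenylpiperazin-1-yl there in place of (1,3-benzoxazol-2-yl)sulfanyl gives a number 17.8 percentage points lower from compound 2 to compound 4 (beyond the scatter), and placing it there in place of chloro gives a number 12.4 percentage points lower from compound 1 to compound 4 (beyond the scatter). The exchange for the sulfur-linked group of compound 3 points the same way, with a number 11.5 percentage points lower from compound 3 to compound 4 (beyond the scatter), so compound 4 stands apart from all three earlier compounds, which remain within the scatter of one another. No supporting measurement is available to explain this separation.

The compounds shown leave open whether the step belongs to the whole 4-phenylpiperazin-1-yl group or to its phenyl, a question that an unsubstituted piperazin-1-yl, a morpholin-4-yl or a simple dimethylamino group at the same carbon would help to settle. They also leave open whether the same order would hold at other concentrations, since each number here describes the size of the read-out at a single concentration and is not a potency.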